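The source may report more compounds than this note shows. Statements on the series, on what has been measured and on what is new or still open speak of the compounds shown alone.

Compound 1 `O=C(Nc1ccc([N+](=O)[O-])cc1)c1cc(F)ccc1O` carries a nitro group on the ring attached to the amide nitrogen. In a functional assay on Jurkat cells (Homo sapiens) for cytotoxicity, read by luminescence and CellTiter-Glo, with a stated time of 3 days (a lower number here means a stronger inhibitor, a higher number a weaker inhibitor), compound 1 gives 940 nM. Two further compounds share a different core, which the comparison with compound 1 does not break down here: compound 3 `O=C(Nc1ccc(Cl)cc1)c1ccc2cccnc2c1O` gives 510 nM in this assay, and compound 2 `O=C(Nc1ccc(Cl)cc1Cl)c1ccc2cccnc2c1O` gives 430 nM. Between these two the only change is chloro in place of hydrogen on an aromatic carbon; it sits on an aromatic carbon of a six-membered aromatic ring of carbon only, ortho to a large group, meta to a chloro group, and produced a step of a 1.2-fold lower number from compound 3 to compound 2 (0.07 log units; within the scatter).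

The unmeasured compound 4 `O=C(Nc1ccc([N+](=O)[O-])cc1Cl)c1cc(F)ccc1O` is built from compound 1 by the same kind of change, (chloro in place of hydrogen on an aromatic carbon), here on an aromatic carbon ortho to a large group and meta to a nitro group rather than meta to a chloro group. Whether a chloro entering beside a nitro-bearing ring behaves like one entering beside a chloro-bearing ring is not shown by these three compounds, and the cores differ.

Resting on the small step seen from compound 3 to compound 2, the step from compound 1 to compound 4 is expected to be about a 1.2-fold lower number from compound 1 to compound 4 (0.07 log units; within the scatter) in this assay. Compound 4 is therefore estimated at 800 nM, with a likely range from 350 nM to 1800 nM.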

Compound 4, half-maximal inhibitory concentration: 530 nM
Compound 4: the middle estimate sits 1.5-fold (0.18 log units) above what was measured; measured number inside the range.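

In this assay, chloro in place of hydrogen on an aromatic carbon gives a 1.8-fold lower number from compound 1 to compound 4 (0.25 log units; within the scatter), so this step on its own does not separate compound 4 from compound 1. Set beside the step on the other core, the change looks much the same on both cores, with no difference that repeated measurements could confirm: the same change on two cores in this assay, a 1.2-fold lower number (0.07 log units; within the scatter) from compound 3 to compound 2 and a 1.8-fold lower number (0.25 log units; within the scatter) from compound 1 to compound 4, 1.5-fold (0.17 log units) apart, within the scatter of two such steps. Going by these compounds alone, this shows only that the change produced no step beyond the scatter on either of these two cores; it does not show that the two steps are truly equal, since a modest real difference could lie hidden in the scatter, nor does one pair per core show how the change would behave on a third core.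

The compounds shown leave open whether any other group on this aromatic carbon, such as a methoxy group, an amine or a carboxylic acid, would give a step beyond the scatter. They also leave open whether chloro would give a similarly small step with some group other than nitro or chloro on the same ring.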